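The source may hold more compounds than are shown below. What is called first, only, known or untested is meant among the compounds shown, and "the series" means these compounds.

Three close relatives share one core and differ only in the halogen that sits on an aromatic carbon. Compound 1 `Nc1ncc(Cc2ccccc2I)c(N)n1` carries iodo, and in an assay for inhibition of Dihydrofolate reductase (Gallus gallus) (a higher number here means a weaker inhibitor, a lower number a stronger inhibitor), compound 1 gives 8710 nM. Compound 2 `Nc1ncc(Cc2ccccc2Br)c(N)n1` carries bromo; in this assay compound 2 gives 12300 nM. Compound 3 `Nc1ncc(Cc2ccccc2Cl)c(N)n1` carries chloro, and in this assay compound 3 gives 17400 nM. The steps of a 1.4-fold higher number from compound 1 to compound 2 (0.15 log units; within the scatter), a 1.4-fold higher number from compound 2 to compound 3 (0.15 log units; within the scatter) and a 2.0-fold higher number from compound 1 to compound 3 (0.30 log units; within the scatter) all stay within the scatter, so the three numbers cannot be told apart with confidence.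

Compound 4 `Nc1ncc(Cc2ccccc2F)c(N)n1` has not yet been measured. Its change from compound 3 is fluoro in place of chloro on an aromatic carbon. Every measured step here swaps one halogen for another at the same place, and none of them moved the number beyond the scatter. A small step is therefore expected again, leaning if anything toward a higher number because a 1.4-fold higher number from compound 1 to compound 2 (0.15 log units; within the scatter) and a 1.4-fold higher number from compound 2 to compound 3 (0.15 log units; within the scatter) both went that way. The expected step is a 1.3-fold higher number from compound 3 to compound 4 (0.10 log units; within the scatter). Compound 4 is estimated at 22000 nM in this assay, with a range from 10000 nM to 50000 nM.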

Compound 4, inhibition constant: 43700 nM
Compound 4: the middle estimate sits 2.0-fold (0.30 log units) below what was measured; measured number inside the range.
By their numbers in this assay, from the lowest: compounds 1, 2 and 3 (each within the scatter of the next); then compound 4.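

Within the data shown here, at this place on the aromatic ring, ortho to a group of 9 heavy atoms, the choice of halogen can matter after all: in this assay, fluoro is the only halogen whose swap moves the number beyond the scatter (a 2.5-fold higher number from compound 3 to compound 4 (0.40 log units; beyond the scatter)). The same holds when fluoro replaces the two larger halogens (a 3.6-fold higher number from compound 2 to compound 4 (0.55 log units; beyond the scatter); a 5.0-fold higher number from compound 1 to compound 4 (0.70 log units; beyond the scatter)). Compound 4 is therefore the weakest inhibitor of the four, although all three steps remain modest, and no measurement at hand bears on why fluoro stands apart.

The compounds shown leave open how this place responds to a group that is not a halogen, such as an amine, a methyl or a methoxy group. They also leave open what any of these halogens would do elsewhere on the same ring.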